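This account rests on a few compounds, and the source may have more. Where it says the series, first, only, none or still open, it means among the compounds named here.

In an ADME assay on L6 cells (Rattus norvegicus) for cytotoxicity (on this read-out higher numbers stand for weaker inhibition and lower numbers for stronger inhibition), three compounds built on one shared core have been measured so far. Compound 1 `CN(C)C12C/C(=N\O)C(C(c3ccc(Cl)cc3)C1)C(c1ccc(Cl)cc1)C2` gives 7820 nM and compound 2 `O/N=C1\CC2(N3CCCC3)CC(c3ccc(Cl)cc3)C1C(c1ccc(Cl)cc1)C2` gives 12700 nM, two numbers that cannot be told apart, as a 1.6-fold higher number from compound 1 to compound 2 (0.21 log units; within the scatter) shows. Compound 3 `O/N=C1/CC2(N3CCCC3)CC(c3ccc(Cl)cc3)C1C(c1ccc(Cl)cc1)C2` gives 5810 nM. Set against that value, with a 2.2-fold lower number from compound 2 to compound 3 (0.34 log units; beyond the scatter), compound 2 stands at the high end of the numbers, level with compound 1.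

The next compound is compound 4 `O/N=C1\CC2(N3CCCCC3)CC(c3ccc(Cl)cc3)C1C(c1ccc(Cl)cc1)C2`, and the change leading to it is piperidin-1-yl in place of pyrrolidin-1-yl on a saturated ring carbon. The swap sits on a saturated ring carbon, and the amine there grows from pyrrolidin-1-yl to piperidin-1-yl. Among the measured compounds shown here, the closest precedent is the swap at the same place from dimethylamino to pyrrolidin-1-yl, a 1.6-fold higher number from compound 1 to compound 2 (0.21 log units; within the scatter), which stayed within the scatter. The step to compound 3, a 2.2-fold lower number from compound 2 to compound 3 (0.34 log units; beyond the scatter), bears less on this question, since it concerns the double bond, and compound 4 keeps that bond drawn as in compound 2. No step beyond the scatter is therefore expected in this assay, perhaps only a slight drift to a lower number. The expected change is a 1.3-fold lower number from compound 2 to compound 4 (0.10 log units; within the scatter). For compound 4 the estimate is 10000 nM, with an expected range from 4500 nM to 22000 nM.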

Compound 4, half-maximal inhibitory concentration: 8750 nM
Beside the measured number, compound 4's estimate is 1.1-fold (0.06 log units) above it; measured number inside the range.
By their numbers in this assay, from the lowest: compounds 3, 1, 4 and 2 (each within the scatter of the next, the first and the last beyond it).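

Among the compounds shown here, with compound 4 in hand, the amine on the saturated ring carbon of the shared core has been read in three forms in this assay, and a second enlargement of that amine again leaves the number where it was: a 1.5-fold lower number from compound 2 to compound 4 (0.16 log units; within the scatter)) and (a 1.1-fold higher number from compound 1 to compound 4 (0.05 log units; within the scatter)) both stay inside the usual scatter. Together with the earlier swap at this place, this means that dimethylamino, pyrrolidin-1-yl and piperidin-1-yl cannot be told apart on this read-out, so within these compounds going from an open amine to a five-membered or six-membered ring moves nothing that can be resolved, and the only step beyond the scatter remains (a 2.2-fold lower number from compound 2 to compound 3 (0.34 log units; beyond the scatter)), which concerns the double bond and not this position. Nothing at hand gives a reason why these three amines read alike.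

What the compounds shown leave open is whether this levelness would hold for an amine of another kind at the same carbon, such as morpholine, a primary amine or a seven-membered ring amine. They also leave open whether the piperidin-1-yl compound with its double bond drawn as in compound 3 would repeat the shift seen in the pyrrolidin-1-yl pair.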